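Adding (dimethylamino)methyl to the cyclohexanone ring of compound 3

This account rests on a few compounds, and the source may have more. Where it says the series, first, only, none or still open, it means among the compounds named here.

Among three compounds measured in a functional assay on CCRF-CEM cells (Homo sapiens) (on this read-out lower numbers stand for stronger inhibition and higher numbers for weaker inhibition), compound 3 `O=C1CCCC/C1=C\c1ccc(OC(=O)c2ccc(Cl)cc2)cc1` gives 41000 nM, the second highest of the three numbers. Its nearest neighbour is compound 1 `CN(C)CC1CCC/C(=C\c2ccc(OC(=O)/C=C/c3ccccc3)cc2)C1=O`, which gives 42800 nM, a gap within the usual scatter, while compound 2 `Cc1ccc(/C=C/C(=O)Oc2ccc(/C=C3\CCCC(CN(C)C)C3=O)cc2)cc1` lies furthest away with 7020 nM, a difference beyond the scatter. Among the measured compounds shown here, the one measured step, a 6.1-fold lower number from compound 1 to compound 2 (0.79 log units; beyond the scatter), concerns a methyl on an aromatic carbon and says nothing about the ring carbon addressed here.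

Compound 4 `CN(C)CC1CCC/C(=C\c2ccc(OC(=O)c3ccc(Cl)cc3)cc2)C1=O` differs from compound 3 in one place: (dimethylamino)methyl in place of hydrogen on a saturated ring carbon. For the measured compounds named here, no measured pair isolates this change. Compound 1 already carries the (dimethylamino)methyl group, and its value sits within the scatter of compound 3, but the two also differ in the ester part, so this comparison is only a hint. Going by the values given here, with no step bearing directly on the change, the step of a 1.0-fold lower number from compound 3 to compound 4 (0.01 log units; within the scatter) is expected to stay within the scatter. Compound 4 is therefore estimated at 40000 nM, with a range from 15000 nM to 110000 nM.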

Compound 4, half-maximal inhibitory concentration: 6150 nM
For compound 4 the middle estimate is 6.5-fold (0.81 log units) above the measured one, and the stated range ends above it.
By their numbers in this assay, from the lowest: compounds 4 and 2 (each within the scatter of the next); then compounds 3 and 1 (each within the scatter of the next).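

In this assay, the step at the saturated ring carbon is now measured directly and lies beyond the scatter (a 6.7-fold lower number from compound 3 to compound 4 (0.82 log units; beyond the scatter)), so (dimethylamino)methyl in place of hydrogen there does change the read-out for this ester. With that group present, the ester part can also matter: 4-chlorophenyl in place of 2-phenylethenyl on the carbonyl carbon gives a step beyond the scatter (a 7.0-fold lower number from compound 1 to compound 4 (0.84 log units; beyond the scatter)), while 4-chlorophenyl in place of 2-(4-methylphenyl)ethenyl stays within it (a 1.1-fold lower number from compound 2 to compound 4 (0.06 log units; within the scatter)). Nothing available explains these steps.

The compounds shown leave open whether a plain methyl or another amine, such as (diethylamino)methyl, on the same ring carbon would give a similar step. They also leave open whether the step carries over to the 2-phenylethenyl and 2-(4-methylphenyl)ethenyl esters.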